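Rat plasma half-life of a diester: phenyl variants

The source may hold more compounds than are shown below. What is called first, only, known or untested is meant among the compounds shown, and "the series" means these compounds.

Measured compounds and their values:
- compound 1, `CC(=O)Oc1ccccc1C(=O)O[C@H]1CO[C@H]2[C@@H]1OC[C@H]2OC(=O)c1ccnn1C`: 0.0642 h
- compound 2, `CC(=O)Oc1ccccc1C(=O)O[C@H]1CO[C@H]2[C@@H]1OC[C@H]2OC(=O)c1ccccc1`: 0.0107 h
- compound 3, `COc1cccc(C(=O)O[C@@H]2CO[C@H]3[C@@H]2OC[C@@H]3OC(=O)c2ccccc2OC(C)=O)c1`: 0.0142 h

In an ADME assay on a cell-free system (plasma, Homo sapiens) for metabolic stability, with Plasma (Rattus norvegicus) as the target, read by HPLC, at pH 7.4 (a lower number here means that the compound disappears faster, a higher number that the compound lasts longer), compound 1 gives the highest of the three numbers. The nearest is compound 3 with 0.0142 h, and the furthest is compound 2 with 0.0107 h.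

Compound 4, `CCOc1cc(OCC)cc(C(=O)O[C@@H]2CO[C@H]3[C@@H]2OC[C@@H]3OC(=O)c2ccccc2OC(C)=O)c1`, differs from compound 1 in one place: 3,5-diethoxyphenyl in place of 1-methyl-1H-pyrazol-5-yl on a carbonyl carbon

Within the data shown here, two measured steps bear on this change, both replacing the same 1-methyl-1H-pyrazol-5-yl on the carbonyl carbon with a six-membered ring of carbon only. Moving to phenyl gave a 6.0-fold lower number from compound 1 to compound 2 (0.78 log units; beyond the scatter). Moving to 3-methoxyphenyl gave a 4.5-fold lower number from compound 1 to compound 3 (0.66 log units; beyond the scatter). Between those two, adding methoxy made little difference: a 1.3-fold higher number from compound 2 to compound 3 (0.12 log units; within the scatter). Whether two ethoxy groups behave like one methoxy is not shown by any measured pair, so the expectation rests on the two aryl-for-pyrazolyl steps alone.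

Compound 4 is therefore expected to fall below compound 1 by a modest step, a 4.3-fold lower number from compound 1 to compound 4 (0.63 log units; beyond the scatter), beyond the scatter. The estimated value for compound 4 in this assay is 0.015 h, with a range from 0.006 h to 0.04 h.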

Compound 4, half-life: 0.0283 h
Compound 4: the middle estimate sits 1.9-fold (0.28 log units) below what was measured; the range from low to high includes it.
By their numbers in this assay, from the lowest: compounds 2, 3 and 4 (each within the scatter of the next, the first and the last beyond it); then compound 1.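

In this assay, swapping the 1-methyl-1H-pyrazol-5-yl for 3,5-diethoxyphenyl on the carbonyl carbon gives a 2.3-fold lower number from compound 1 to compound 4 (0.36 log units; beyond the scatter), so compound 1 still has the highest number, and this third ring of carbon only also fails to match it. The new result also shows that what the carbon ring carries can matter at this position: the change from plain phenyl gives a 2.6-fold higher number from compound 2 to compound 4 (0.42 log units; beyond the scatter), the first step among these rings to go beyond the scatter, whereas the change from 3-methoxyphenyl gives a 2.0-fold higher number from compound 3 to compound 4 (0.30 log units; within the scatter), which stays within it. No measurement available here explains these differences.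

The compounds shown leave open whether the step from phenyl depends on having two groups on the ring or on their being ethoxy rather than methoxy, a question that a ring with a single ethoxy group or two methoxy groups could address. They also leave open how this position would respond to a ring bearing an amine or a carboxylic acid, to a longer chain such as butoxy, or to a pyridine ring in place of the pyrazole.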